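Repositioning the Pyridine Nitrogen on a Sulfonylurea Core

The source may hold more compounds than are shown below. What is called first, only, known or untested is meant among the compounds shown, and "the series" means these compounds.

Compound 1 `COc1cc(F)c(CN2C(=O)N(c3cc(OC)nc(OC)c3)S(=O)(=O)c3ccccc32)c(F)c1` and compound 2 `COc1cc(F)c(CN2C(=O)N(c3cnc(OC)c(OC)c3)S(=O)(=O)c3ccccc32)c(F)c1` share one core and differ only in the dimethoxypyridine attached to the ring nitrogen. In an assay on HEK293 cells for displacement of a labelled ligand from Orexin receptor type 2 (Homo sapiens), read by scintillation counting, with a stated time of 90 min (on this read-out higher numbers stand for weaker inhibition and lower numbers for stronger inhibition), compound 1 gives 0.251 nM, and compound 2 gives 0.398 nM. Compound 2 thus stands at the higher of the two numbers, yet the step of a 1.6-fold higher number from compound 1 to compound 2 (0.20 log units; within the scatter) lies within the scatter, so the two cannot be ordered. Compound 3 `COc1cc(F)c(CN2C(=O)N(c3ccc(OC)c(OC)n3)S(=O)(=O)c3ccccc32)c(F)c1` keeps the same atoms as compound 2, joined differently: 5,6-dimethoxypyridin-2-yl in place of 5,6-dimethoxypyridin-3-yl on an amide-type nitrogen in a ring. Going by the values given here, only one measured step bears on this kind of change, the one from compound 1 to compound 2, and it stayed within the scatter. A further shift of the same ring nitrogen and methoxy groups is therefore expected to give a step of about a 1.3-fold higher number from compound 2 to compound 3 (0.10 log units; within the scatter), with no direction anticipated beyond the scatter. Compound 3 is estimated at 0.5 nM, in a range from 0.15 nM to 1.6 nM.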

Compound 3, inhibition constant: 0.2 nM
Beside the measured number, compound 3's estimate is 2.5-fold (0.40 log units) above it; low and high end bracket the measured number.
By their numbers in this assay, from the lowest: compounds 3, 1 and 2 (each within the scatter of the next).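

Compound 3 adds a third arrangement of the same atoms on the amide-type nitrogen in a ring, and this assay gives a 2.0-fold lower number from compound 2 to compound 3 (0.30 log units; within the scatter) and a 1.3-fold lower number from compound 1 to compound 3 (0.10 log units; within the scatter). With the earlier step, all three pairs now lie within the scatter, so the three dimethoxypyridines cannot be ordered, and moving the ring nitrogen and the methoxy groups at this position has so far produced no measurable separation. No supporting evidence bears on why these numbers stay so close.

Going by these compounds, what remains open is whether this insensitivity extends past rearrangements of the same atoms. An amine or a carboxylic acid in place of a methoxy group, or an ethoxy chain there, might or might not move the number beyond the scatter, and these three compounds cannot tell which.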